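A few compounds are considered here, and "the series" means these few. Any claim that something is new, unique, unknown or untested is made for them only; others in the source may bear on it.

Working notes on the series.

Three compounds have a number in an ADME assay on a cell-free system (plasma, Homo sapiens) for metabolic stability (a lower number here means that the compound disappears faster, a higher number that the compound lasts longer), so far. Compound 1 `C[C@H](NC(=O)[C@H](N)CC(=O)OCc1ccc(F)cc1)C(=O)O` gives 4.33 h. Compound 2 `Cc1nccn1CCOC(=O)[C@@H](C)c1ccc(-c2ccccc2)c(F)c1` gives 5.92 h. Compound 3 `O=C(OC[C@H]1O[C@@H](n2cc(F)c(=O)[nH]c2=O)C[C@@H]1OC(=O)[C@@H]1CCCN1)[C@@H]1CCCN1` gives 0.1 h. On these numbers compound 2 stands at the top of the three, but the gap to compound 1 lies within the scatter of repeated measurements and says nothing about order; only compound 3 sits clearly apart, well beyond the scatter and far below compound 2.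

The next compound, compound 4 `Cc1nccn1CCOC(=O)[C@H](C)c1ccc(-c2ccccc2)c(F)c1`, is the stereoisomer of compound 2: the two compounds have the same atoms and bonds and differ only in configuration as drawn: 1 of 1 stereo elements differ; a stereocentre at a saturated chain carbon is drawn S in compound 2 and R in compound 4. Within the data shown here, no pair of measured compounds in this set differs by such a change, so there is nothing in the data from which a direction or size for an inversion at that centre can be read. With the same atoms and bonds present, the working expectation is no step beyond the scatter, while allowing that the two configurations may not behave alike in this assay.

Compound 4 is therefore estimated at 5.9 h, within 2.5 h to 14 h, which means an expected step of a 1.0-fold lower number from compound 2 to compound 4 (0.00 log units; within the scatter).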

Compound 4, half-life: 0.633 h
For compound 4 the middle estimate is 9.3-fold (0.97 log units) above the measured one; measured number outside the range, below it.
By their numbers in this assay, from the lowest: compound 3; then compound 4; then compounds 1 and 2 (each within the scatter of the next).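

In this assay, the stereocentre at the saturated chain carbon proves to matter: inverting it from S to R gives a 9.4-fold lower number from compound 2 to compound 4 (0.97 log units; beyond the scatter). Among these compounds, the earlier compounds held no pair that could show this, and the step is now the only matched change, so the configuration at this centre is a position the read-out responds to, not a silent detail. The step can be assigned to the inversion alone because nothing else in the structures changes: the fact that compounds 2 and 4 differ only in the configuration as drawn

This single pair shows the size and direction of the effect but not how it arises. From the compounds shown here alone, whether it holds at a similar stereocentre elsewhere is unknown. Also open, going by these compounds, is whether the gap between the two configurations would persist with a longer chain in place of the methyl group on that carbon.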